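The source may report more compounds than this note shows. Statements on the series, on what has been measured and on what is new or still open speak of the compounds shown alone.

Notes on a small amide series tested in a toxicity assay on THP-1 cells (Homo sapiens) for inhibition; on this read-out lower numbers stand for higher toxicity in this test and higher numbers for lower toxicity in this test. Compound 1 `Cn1c(-c2ccc(C#N)cc2)cnc1NC(=O)c1ccc(F)cc1` reports only an assay limit, > 50000 nM. Compound 2 `Cn1c(-c2cccc([N+](=O)[O-])c2)cnc1NC(=O)c1ccc(F)cc1` likewise reaches only a limit, > 50000 nM. Compound 3 `COc1ccc(-c2cnc(NC(=O)c3ccccc3F)n2C)cc1` also gives a limit rather than a number, > 100000 nM. For the measured compounds named here, compound 3 thus stands at the limit of > 100000 nM in this assay, at which 1 of the 3 values shown sits, while the two other compounds sit at the limit of > 50000 nM in this assay, at which 2 of the 3 values shown sit; no numeric value is available in this assay for any of the three, so no measured step can be sized. Compound 4 `COc1ccc(-c2cnc(NC(=O)C3CCCC3)n2C)cc1` carries cyclopentyl in place of 2-fluorophenyl on a carbonyl carbon. The change is expected to move this assay by no more than the scatter, a number no higher from compound 3 to compound 4 (the limit leaves the size open). Compound 4 is estimated at 100000 nM, within the range 30000 nM to 300000 nM, most likely again reported only as a limit.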

Compound 4, half-maximal cytotoxic concentration: > 100000 nM
Compound 4 gave a limit, no number (the forecaster's own chance of this, stated with the estimate: 80%); the middle value lies on the limit itself.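

Compound 3 and compound 4 each give only a limit in this assay, and the step between them cannot be read. The compounds shown leave open where a numeric value for any of them would fall, and whether swapping 2-fluorophenyl for cyclopentyl moves it.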